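A few compounds are considered here, and "the series" means these few. Any claim that something is new, unique, unknown or untested is made for them only; others in the source may bear on it.

Of the compounds shown here, two sharing a core have so far been measured in a functional assay on Ehrlich cells (Mus musculus) for inhibition (a higher number here means a weaker inhibitor, a lower number a stronger inhibitor), and both give numbers. Compound 1 `O=C(O)c1cnc2cc(OCc3c(Cl)c(Cl)c(Cl)c(Cl)c3Cl)ccc2c1O` gives 42700 nM in this test, while compound 2 `CN(C)c1ccc2c(O)c(C(=O)O)cnc2c1` gives 468000 nM in the same test. Compound 2 holds the higher of the two numbers, and the gap lies beyond the scatter, so it is the weaker inhibitor of the pair. Compound 3 `COc1ccc2c(O)c(C(=O)O)cnc2c1` has not yet been measured and differs from compound 2 by methoxy in place of dimethylamino on an aromatic carbon. Among the compounds with values here, no measured pair shows this exchange, so its size remains unknown from the data. In this assay no step beyond the scatter is expected, in either direction. The estimated change, a 1.2-fold lower number from compound 2 to compound 3 (0.07 log units; within the scatter), would stay within that scatter. Compound 3 is estimated at 400000 nM with an expected range of 150000 nM to 1000000 nM overall.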

Compound 3, half-maximal inhibitory concentration: 525000 nM
Beside the measured number, compound 3's estimate is 1.3-fold (0.12 log units) below it; measured number inside the range.
By their numbers in this assay, from the lowest: compound 1; then compounds 2 and 3 (each within the scatter of the next).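

In this assay, within the data shown here, methoxy in place of dimethylamino on an aromatic carbon gives a 1.1-fold higher number from compound 2 to compound 3 (0.05 log units; within the scatter) and so provides the first step that can be read at this position. The two groups can therefore be exchanged here without a change beyond the scatter, even though dimethylamino has one heavy atom more than methoxy and the atom bound to the ring is oxygen instead of nitrogen. Compound 2 and compound 3 cannot be told apart in this test, and nothing available explains this result.

Still open, on these data alone, is whether a primary amine, an ethoxy group or a fluorine atom on this carbon would move the number beyond the scatter. Also open, as far as these compounds go, is whether the same exchange would stay within the scatter on another aromatic carbon of the shared core.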